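The compounds below may be only part of what the source reports. "The series", "measured", "known", "first", "only" and "open" are said of these compounds alone.

Compound 3 `CC1CCN(C2CCN(S(=O)(=O)c3cccc(-c4ccc(F)cc4)c3)CC2)CC1` gives 12 nM in a functional assay on DLD-1 cells (Homo sapiens) for antiproliferative activity, read by CellTiter-Glo, with a stated time of 72 h (a higher number here means a weaker inhibitor, a lower number a stronger inhibitor), the lowest of the three numbers measured; compound 2 `Cc1ccc(S(=O)(=O)N2CCC(N3CCC(C)CC3)CC2)cc1C` gives 24 nM, which lies within the scatter of that result, while compound 1 `CC1CCN(C2CCN(S(=O)(=O)c3cccnc3)CC2)CC1` gives 2400 nM, far higher. Compound 4 `CC1CCN(C2CCN(S(=O)(=O)c3cccc(Br)c3)CC2)CC1` differs from compound 3 by bromo in place of 4-fluorophenyl on an aromatic carbon. Among the compounds with values here, the one measured step that touches the group on the sulfonyl sulfur, a 100-fold lower number from compound 1 to compound 2 (2.00 log units; beyond the scatter), shows that this part of the molecule can move the number a great deal. Yet compound 2, carrying only small substituents there, and compound 3, carrying the larger one, give numbers close to each other, so the step is expected to be a 2.1-fold higher number from compound 3 to compound 4 (0.32 log units; beyond the scatter). Compound 4 is therefore estimated at 25 nM, between 8 nM and 80 nM.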

Compound 4, half-maximal inhibitory concentration: 3.2 nM
Estimate against measurement, compound 4: 7.8-fold (0.89 log units) above, and the stated range ends above it.
By their numbers in this assay, from the lowest: compound 4; then compounds 3 and 2 (each within the scatter of the next); then compound 1.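

A single bromo on the aromatic ring gives a lower number than the whole 4-fluorophenyl group (a 3.8-fold lower number from compound 3 to compound 4 (0.57 log units; beyond the scatter)), so a second aromatic ring at this place is not needed for strong activity in this assay. The 3-bromophenyl group also beats both other sulfonyl groups (a 7.5-fold lower number from compound 2 to compound 4 (0.88 log units; beyond the scatter); a 750-fold lower number from compound 1 to compound 4 (2.88 log units; beyond the scatter)). Nothing measured here explains these steps.

Still open, as far as these compounds go, is whether bromine itself matters, or whether chloro, methyl or an amine at this place would give a similar number.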